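This account rests on a few compounds, and the source may have more. Where it says the series, first, only, none or still open, it means among the compounds named here.

For the measured compounds named here, in a physicochemical assay for activation, with a stated time of 60 min (on this read-out higher numbers stand for an effect only at larger amounts of compound and lower numbers for an effect already at smaller amounts), compound 1 `O=C1NC(=O)/C(=C\c2ccc(Cl)cc2)C2=C1CCCC2` gives 500 nM, the lower of the two numbers measured so far, while compound 2 `O=C1NC(=O)/C(=C\c2ccco2)C2=C1CCCC2` gives 18000 nM. Compound 3 `O=C1NC(=O)/C(=C\c2ccc(F)cc2)C2=C1CCCC2` differs from compound 1 in one place: fluoro in place of chloro on an aromatic carbon, with fluoro in place of chloro on an aromatic carbon, para to a large group. Going by the values given here, no measured pair yet shows what this swap does. The expected change is therefore only a small move toward a higher number, perhaps no larger than the usual scatter, estimated as a 1.6-fold higher number from compound 1 to compound 3 (0.20 log units; within the scatter). For compound 3 the estimated value is 800 nM, with an expected range of 250 nM to 2500 nM.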

Compound 3, half-maximal effective concentration: 60000 nM
Compound 3: the middle estimate sits 75-fold (1.88 log units) below what was measured; measured number above the stated range.
By their numbers in this assay, from the lowest: compound 1; then compound 2; then compound 3.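

In this assay the change of chloro to fluoro gives a 120-fold higher number from compound 1 to compound 3 (2.08 log units; beyond the scatter) even though only one heavy atom leaves and one enters. This position on the aromatic ring is therefore highly sensitive to which group it carries, and even this small exchange cannot be treated as neutral here. Nothing at hand explains the size of this step. The compounds shown leave open how bromo, methyl or methoxy at the same position would compare with chloro and fluoro.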